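Amide-nitrogen side-chain swap: exposure notes

A few compounds are considered here, and "the series" means these few. Any claim that something is new, unique, unknown or untested is made for them only; others in the source may bear on it.

Compound 1 (`CCC(CC)N(CCN(C)C(=O)CCC(=O)O)Cc1cccc(C(=O)Nc2sc3c(c2C(=O)c2cnn(-c4ccc(Cl)c(C(F)(F)F)c4)c2)CCC(C)(C)C3)c1`) and compound 2 (`CCC(CC)N(CCN(C)C(=O)CCC(=O)NCCOCCOCCOCCO)Cc1cccc(C(=O)Nc2sc3c(c2C(=O)c2cnn(-c4ccc(Cl)c(C(F)(F)F)c4)c2)CCC(C)(C)C3)c1`) share the core. In an ADME assay on the whole organism (Rattus norvegicus, strain Sprague-Dawley) for pharmacokinetics, at a dose of 1 mg/kg by the intravenous route (on this read-out lower numbers stand for lower exposure and higher numbers for higher exposure at the dose given), compound 1 gives 3070 ng.h/mL and compound 2 gives 1570 ng.h/mL, two values within the usual scatter of each other. Compound 3 (`CCC(CC)N(CCN(C)C(=O)CCC(=O)NC(C)(C)C(=O)NCCN(C)C)Cc1cccc(C(=O)Nc2sc3c(c2C(=O)c2cnn(-c4ccc(Cl)c(C(F)(F)F)c4)c2)CCC(C)(C)C3)c1`) carries one change relative to compound 2: a group of 11 heavy atoms (8 carbon, 2 nitrogen, 1 oxygen; no ring) in place of a group of 12 heavy atoms (8 carbon, 4 oxygen; no ring), on an amide-type nitrogen. The entering group is 1-((2-(dimethylamino)ethyl)carbamoyl)-1-methylethyl, on an amide-type nitrogen. Going by the values given here, no measured step bears on this change, so no movement beyond the scatter is expected in this assay. The estimated step of a 1.1-fold lower number from compound 2 to compound 3 (0.05 log units; within the scatter) stays within that scatter. For compound 3 the expected value is 1400 ng.h/mL, with an estimated range of 550 ng.h/mL to 3300 ng.h/mL.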

Compound 3, area under the concentration-time curve in the Rattus norvegicus assay: 2580 ng.h/mL
Compound 3: the middle estimate sits 1.8-fold (0.27 log units) below what was measured; the measured number falls inside the stated range.
By their numbers in the Rattus norvegicus assay, from the lowest: compounds 2, 3 and 1 (each within the scatter of the next).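

In the Rattus norvegicus assay the 1-((2-(dimethylamino)ethyl)carbamoyl)-1-methylethyl group on the amide-type nitrogen gives a 1.6-fold higher number from compound 2 to compound 3 (0.22 log units; within the scatter) and, set against hydroxy on the carbonyl carbon, a 1.2-fold lower number from compound 1 to compound 3 (0.08 log units; within the scatter), so a chain carrying nitrogen also stays within the scatter at this position. In a physicochemical assay for solubility, in simulated intestinal fluid, at pH 5.1 (on this read-out lower numbers stand for lower solubility and higher numbers for higher solubility), compound 2 gives a limit, > 384 ug/mL. In the physicochemical assay compound 3 also gives a limit, > 434 ug/mL, and no step can be read from these limits.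

No measurement shown accounts for the exposure numbers. From the compounds shown here alone, whether a morpholine ring or a longer chain on this nitrogen moves exposure beyond the scatter remains open.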